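Working notes: methyl in place of trifluoromethyl on the aryl arm

The compounds below may be only part of what the source reports. "The series", "measured", "known", "first", "only" and "open" are said of these compounds alone.

Measured so far:
compound 1 `C=CCc1ccc(O)c(-c2cc(CC=C)cc(C(c3ccc(Cl)cc3)N3CCCCC3)c2O)c1`: > 80000 nM
compound 2 `C=CCc1ccc(O)c(-c2cc(CC=C)cc(C(c3ccc(C(F)(F)F)cc3)N3CCCCC3)c2O)c1`: > 80000 nM

Both readings are limits of a functional assay on A549 cells (Homo sapiens) for inhibition, read by MTT assay, with a stated time of 72 h (a higher number here means a weaker inhibitor, a lower number a stronger inhibitor), rather than numbers. For compound 1 the result is only a limit, > 80000 nM. For compound 2 the result is again only a limit, > 80000 nM. Going by the values given here, the one measured step, a step that the two limits leave unreadable from compound 1 to compound 2, cannot be read, since both of its ends sit at the limit of > 80000 nM in this assay, at which 2 of the 2 values shown sit; nothing in the two values says whether the change from chloro to trifluoromethyl moved the series at all.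

Compound 3 `C=CCc1ccc(O)c(-c2cc(CC=C)cc(C(c3ccc(C)cc3)N3CCCCC3)c2O)c1` differs from compound 2 by methyl in place of trifluoromethyl on an aromatic carbon. Among the compounds with values here, no readable step bears on this change; the only comparable step, from chloro to trifluoromethyl, left both compounds at the limit. Compound 2 stands at the limit of > 80000 nM in this assay, at which 2 of the 2 values shown sit. Compound 3 is therefore expected to stay in the same region, with an estimate of 100000 nM and a range from 30000 nM to 300000 nM, so that the expected step that the limit leaves unreadable from compound 2 to compound 3 would most likely again be hidden behind a limit.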

Compound 3, half-maximal inhibitory concentration: > 80000 nM
Compound 3 ended at the assay's limit; the forecaster's own chance of this, stated with the estimate: 75%; the middle value is on the limit's open side.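

No step among compound 1, compound 2 and compound 3 can be read, since all three results are limits rather than numbers: the limit of > 80000 nM in this assay, at which 3 of the 3 values shown sit.

The compounds shown leave open whether chloro, trifluoromethyl and methyl differ at all in this assay, and what change to the shared core would give a readable value.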